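Iodo for Trifluoromethyl: A Step from Compound 2

The compounds below may be only part of what the source reports. "The series", "measured", "known", "first", "only" and "open" are said of these compounds alone.

Of the compounds shown here, two have been measured so far. Compound 1 `Nc1ccn([C@H]2C[C@H](N)[C@@H](CO)O2)c(=O)n1` gives 0.7 uM in a functional assay on L1210 cells (Mus musculus) for inhibition; on this read-out lower numbers stand for an effect already at smaller amounts and higher numbers for an effect only at larger amounts of compound. Compound 2 `N[C@@H]1C[C@H](n2cc(C(F)(F)F)c(=O)[nH]c2=O)O[C@@H]1CO` gives 150 uM in this assay, the higher of the two numbers; the gap to compound 1 lies well beyond the usual scatter, so compound 2 acts only at clearly larger amounts than compound 1.

Compound 3 `N[C@@H]1C[C@H](n2cc(I)c(=O)[nH]c2=O)O[C@@H]1CO` has not yet been measured in this assay. It differs from compound 2 in one place: iodo in place of trifluoromethyl on an aromatic carbon. Among the compounds with values here, no measured pair shows this change, so its size cannot be read from any step already known.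

Both compound 2 and compound 3 share the same core with the same amino and hydroxymethyl groups, and differ only by the group on the aromatic carbon. Within the data shown here, with no comparable step measured, a modest move is expected, if any, and the direction is uncertain. For compound 3 the expected step is a 2.5-fold lower number from compound 2 to compound 3 (0.40 log units; beyond the scatter), toward a somewhat lower number. The estimate for compound 3 in this assay is 60 uM, with a range from 10 uM to 300 uM.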

Compound 3, concentration for half-maximal effect: 400 uM
Estimate against measurement, compound 3: 6.7-fold (0.82 log units) below; measured number above the stated range.
By their numbers in this assay, from the lowest: compound 1; then compound 2; then compound 3.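

In this assay, within the data shown here, the exchange of trifluoromethyl for iodo gives a 2.7-fold higher number from compound 2 to compound 3 (0.43 log units; beyond the scatter) and so provides the first measured step at this aromatic carbon of the six-membered aromatic ring with 2 nitrogen. The step is modest but beyond the scatter, and it shows that, between these two groups on the shared core, iodo goes with the higher number and trifluoromethyl with the lower. The amino and hydroxymethyl groups stay the same across this pair, so the step belongs to this one change, but no available measurement bears on what lies behind it.

As far as these compounds go, with only trifluoromethyl and iodo compared at this carbon, it remains open whether a methyl, a chloro or an amine there would give a number lower than that of compound 2, higher than that of compound 3, or one in between. Compound 1 differs from compound 2 and compound 3 in more than one place, so its number cannot show what this position alone contributes.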